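The source may hold more compounds than are shown below. What is called first, only, known or untested is meant among the compounds shown, and "the series" means these compounds.

Measured in a functional assay on U-87MG ATCC cells (Homo sapiens) for inhibition; a lower number here means a stronger inhibitor, a higher number a weaker inhibitor:
- Compound 1 `COc1cc(/C=C/C(=O)c2cccc(NC(=O)c3ccc(Cl)cc3)c2)ccc1O`: > 50 ug/mL (a limit)
- Compound 2 `COc1cc(/C=C/C(=O)c2cccc(N)c2)ccc1O`: 7.71 ug/mL
- Compound 3 `COc1cc(/C=C/C(=O)c2cccc(NC(=O)c3ccc(Cl)cc3Cl)c2)ccc1O`: > 50 ug/mL (a limit)

Compound 3 thus sits at the limit of > 50 ug/mL in this assay, at which 2 of the 3 values shown sit, so its true position is not known. Compound 4 `COc1cc(/C=C/C(=O)c2cccc(NC(C)=O)c2)ccc1O` carries methyl in place of 2,4-dichlorophenyl on a carbonyl carbon, that is, methyl in place of 2,4-dichlorophenyl on a carbonyl carbon. Within the data shown here, two measured steps bear on this change: an at least 6.4-fold higher number from compound 2 to compound 3 (0.81 log units; beyond the scatter) and an at least 6.4-fold lower number from compound 1 to compound 2 (0.81 log units; beyond the scatter), both beyond the scatter. Neither shows what a small acetyl does, since compound 4 keeps the amide but loses the aromatic ring. A move partway towards compound 2 at 7.71 ug/mL is therefore expected, with a modest drop in the number. The expected change is an at least 2.0-fold lower number from compound 3 to compound 4 (0.30 log units; that floor lies within the scatter). For compound 4 the estimated value is 25 ug/mL, with an expected range of 9 ug/mL to 60 ug/mL.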

Compound 4, half-maximal inhibitory concentration: > 50 ug/mL
Compound 4 gave a limit, no number; the forecaster's own chance of this, stated with the estimate: 35%; middle value at least 2.0-fold (0.30 log units) away from the limit.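

In this assay, even acetyl on the nitrogen gives an at least 6.4-fold higher number from compound 2 to compound 4 (0.81 log units; beyond the scatter), a step that rests on a limit rather than a number. An aromatic ring on the carbonyl is therefore not needed for the loss seen with the larger amides. The steps among compound 1, compound 3 and compound 4 cannot be read, as all three stay at one limit: the limit of > 50 ug/mL in this assay, at which 3 of the 4 values shown sit.

On these data alone, how far these amides lie beyond that limit stays open. So does whether a methylamine or a sulfonamide on that nitrogen would keep the value of compound 2.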